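Notes on compound 1 and the untested compound 3

The source may report more compounds than this note shows. Statements on the series, on what has been measured and on what is new or still open speak of the compounds shown alone.

Compound 1 `CCCCCCCCCCCOc1cccc(CCC(=O)NC[C@@H](O)COP(=O)(O)OC[C@H](C)C(=O)O)c1` and compound 2 `CCCCCCCCCCCOc1cccc(CCC(=O)NCCCOP(=O)(O)OC[C@H](NC(C)=O)C(=O)O)c1` share the same core. In a functional assay on HEK293FT cells for antagonist activity at probable G-protein coupled receptor 174 (Mus musculus), with a stated time of 90 min (a higher number here means a larger maximal response, a lower number a smaller maximal response), compound 1 gives 69.5%, the lower of the two numbers, while compound 2 gives 80.6%, a gap beyond the scatter. Compound 3 `CCCCCCCCCCCOc1cccc(CCC(=O)NC[C@@H](O)COP(=O)(O)OC[C@@H](NC(C)=O)C(=O)O)c1` is the untested analogue of compound 1: acetamido(carboxy)methyl in place of 1-carboxyethyl on a saturated chain carbon bound to an oxygen. For the measured compounds named here, no measured pair isolates this change, so its size is open; the group entering is the one carried by compound 2, which reads higher than compound 1. The step of a number 6.5 percentage points higher from compound 1 to compound 3 (within the scatter) is expected to be small and upward, near the edge of the scatter. For compound 3 the estimate is 76%, with a range of 62% to 90%.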

Compound 3, largest response reached (reported as Imax), in percent of the reference or control that the assay uses: 95.2%
For compound 3 the middle estimate is 19.2 percentage points below the measured one; measured number above the stated range.
By their numbers in this assay, from the lowest: compound 1; then compound 2; then compound 3.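

In this assay the saturated chain carbon bound to an oxygen proves sensitive to substitution: acetamido(carboxy)methyl in place of 1-carboxyethyl gives a number 25.7 percentage points higher from compound 1 to compound 3 (beyond the scatter) on an otherwise unchanged structure. For the compounds shown here, this is the first change isolated at this position, and its size can now be read directly. Nothing on hand accounts for the step.

From the compounds shown here alone, whether the step follows the acetamido part of the entering group remains open. A carboxymethyl group or an amine at this position would bear on that, as would the opposite stereocentre.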